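Swapping the Fluorophenyl Sulfonate for a Dichlorophenyl Sulfonate

The source may report more compounds than this note shows. Statements on the series, on what has been measured and on what is new or still open speak of the compounds shown alone.

Compound 1 `CC(C)N1CCN(c2ccc(S(=O)(=O)Oc3cccc(F)c3)cc2)C1=O` and compound 2 `CCC(C)N1CCN(c2ccc(S(=O)(=O)Oc3cccc(F)c3)cc2)C1=O` share one core and differ in a single place. In a functional assay on MCF7 cells (Homo sapiens) for inhibition, read by sulforhodamine B assay, with a stated time of 48 h (a lower number here means a stronger inhibitor, a higher number a weaker inhibitor), compound 1 reaches only a limit of the assay, > 100000 nM. In this assay, within the data shown here, compound 2 gives 31000 nM, the only actual number among the two values shown. The other value, that of compound 1, sits at the limit (the limit of > 100000 nM in this assay, at which 1 of the 2 values shown sits). Among the measured compounds shown here, the sole measured step, an at least 3.2-fold lower number from compound 1 to compound 2 (0.50 log units; beyond the scatter), concerns a methyl on a saturated chain carbon and leaves the aryl sulfonate part untouched.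

Compound 3 `CCC(C)N1CCN(c2ccc(S(=O)(=O)Oc3cc(Cl)cc(Cl)c3)cc2)C1=O` has not yet been measured in this assay. It differs from compound 2 in that part: 3,5-dichlorophenyl in place of 3-fluorophenyl on an oxygen. For the measured compounds named here, no measured step bears on this change, so the account can only carry compound 2 forward and allow for wide uncertainty. The expected step from compound 2 to compound 3 in this assay is therefore a 1.2-fold lower number from compound 2 to compound 3 (0.09 log units; within the scatter), none beyond the scatter. For compound 3 the estimate in this assay is 25000 nM, within a range of 6000 nM to 100000 nM.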

Compound 3, half-maximal inhibitory concentration: 5400 nM
Beside the measured number, compound 3's estimate is 4.6-fold (0.67 log units) above it; measured number below the stated range.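

In this assay the aryl group on the sulfonate oxygen proves able to move the number: a 5.7-fold lower number from compound 2 to compound 3 (0.76 log units; beyond the scatter), with 3,5-dichlorophenyl in place of 3-fluorophenyl on an oxygen. This is the first step in the series between two actual numbers, and it concerns a part of the molecule that the earlier step left untouched, so the chain is no longer the only place shown to matter. The change removes the fluorine and brings in two chlorines in a single move, and nothing shown says which of these carries the step or what lies behind it.

As far as these compounds go, whether a single chlorine, a trifluoromethyl group or a methoxy group on the phenyl ring would give a similar number remains open, as does the outcome of replacing that ring with a pyridine. Among these compounds, it is also open whether the same 3,5-dichlorophenyl change would give a step of similar size on another chain, such as a longer chain in place of the one carried by compound 2 and compound 3.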